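The source may hold more compounds than are shown below. What is called first, only, known or untested is meant among the compounds shown, and "the series" means these compounds.

For the measured compounds named here, compound 1 `Nc1nc(N)nc(-c2ccccc2Br)n1` gives 26% in a functional assay on the whole organism with Rattus norvegicus as the target, at a dose of 20 mg/kg by the intraperitoneal route (a lower number here means less inhibition, a higher number more inhibition at the dose given (going by the name of the read-out)), the highest of the three numbers measured so far; compound 2 `CCc1ccccc1-c1nc(N)nc(N)n1` gives 20% and compound 3 `Nc1nc(N)nc(-c2ccccc2[N+](=O)[O-])n1` gives 11%. Of the steps among them, a number 6 percentage points lower from compound 1 to compound 2 (within the scatter) lies within the scatter, a number 15 percentage points lower from compound 1 to compound 3 (beyond the scatter) lies beyond it and is modest, and a number 9 percentage points lower from compound 2 to compound 3 (within the scatter) lies within the scatter again. Compound 4 `Nc1nc(N)nc(-c2ccc(Cl)cc2Br)n1` differs from compound 1 by chloro in place of hydrogen on an aromatic carbon. None of the three measured steps bears directly on this change: each of them exchanges the bromo, ethyl or nitro group for one another, and none adds a further group to that ring while keeping bromo in place. The measured steps thus give no argument for a shift beyond the scatter in this assay, and the step is expected to be no change at the digits printed from compound 1 to compound 4 (within the scatter). Compound 4 is therefore estimated to give 26% in this assay, with a range from 10% to 42%.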

Compound 4, a percentage reported as inhibition, in the whole organism at one dose (the size of the read-out at that dose, not a potency): 96%
For compound 4 the middle estimate is 70 percentage points below the measured one; measured number outside the range, above it.
By their numbers in this assay, from the lowest: compounds 3, 2 and 1 (each within the scatter of the next, the first and the last beyond it); then compound 4.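

In this assay, putting chloro in place of hydrogen on the aromatic carbon meta to the bromo group and para to a group of 8 heavy atoms gives a number 70 percentage points higher from compound 1 to compound 4 (beyond the scatter) and is the largest step shown. Compounds 1, 2 and 3 all carry hydrogen at this carbon, so they could not reveal that a single chlorine atom here moves the read-out far more than the exchanges among bromo, ethyl and nitro. Nothing at hand accounts for the size of this step.

On these data alone, it remains open whether a fluoro, methyl or methoxy group on the same carbon would give a comparable step, or whether it is specific to chloro. As far as these compounds go, it is equally open whether chloro here would act alike with ethyl or nitro in place of bromo.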